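The source may report more compounds than this note shows. Statements on the series, on what has been measured and on what is new or still open speak of the compounds shown alone.

Compound 1 `CCCn1c(=O)[nH]c2nc(-c3ccc(S(=O)(=O)N4CCN(c5ccccc5Br)CC4)cc3)[nH]c2c1=O` gives 0.137 nM in an assay on CHO cells for displacement of a labelled ligand from adenosine receptor A2b (Homo sapiens), read by scintillation counting, with a stated time of 75 min, in the presence of a further agent that is not named here; a lower number here means a stronger inhibitor, a higher number a weaker inhibitor.
Compound 2 `CCCn1c(=O)c2[nH]c(-c3ccc(S(=O)(=O)N4CCN(c5ccc(Cl)cc5)CC4)cc3)nc2n(CC)c1=O` gives 4.31 nM in this assay.
Compound 3 `CCCn1c(=O)c2[nH]c(-c3ccc(S(=O)(=O)N4CCN(c5ccc(Cl)cc5)CC4)cc3)nc2n(C)c1=O` gives 1.91 nM in this assay.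

Among these three, compound 1 has the lowest number, and both gaps to it lie beyond the scatter: compound 3 sits above it, and compound 2 sits higher still. Going by the values given here, the only step between two measured compounds is a 2.3-fold lower number from compound 2 to compound 3 (0.35 log units; beyond the scatter), which concerns the group on a nitrogen of the shared core and not the piperazine-linked ring.

Compound 4 `CCCn1c(=O)[nH]c2nc(-c3ccc(S(=O)(=O)N4CCN(c5ccccc5)CC4)cc3)[nH]c2c1=O` differs from compound 1 in one place: hydrogen in place of bromo on an aromatic carbon. Among the compounds with values here, no measured pair shows what removing a halogen from this ring does, so the direction of the step has to be inferred from general experience rather than from these data. Since the change strips a single heavy atom from a compound that already gives the lowest number, a modest weakening is expected for compound 4, at the edge of or somewhat beyond the scatter.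

On that basis compound 4 is estimated at 0.4 nM in this assay, within a range from 0.1 nM to 1.6 nM, which amounts to an expected step of a 2.9-fold higher number from compound 1 to compound 4 (0.47 log units; beyond the scatter).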

Compound 4, inhibition constant: 0.643 nM
Compound 4: middle estimate off by 1.6-fold (0.21 log units), on the low side; the measured number falls inside the stated range.
By their numbers in this assay, from the lowest: compound 1; then compound 4; then compound 3; then compound 2.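

Going by these compounds alone, removing the bromo gives a 4.7-fold higher number from compound 1 to compound 4 (0.67 log units; beyond the scatter) in this assay, the first measured change on the piperazine-linked ring, so this single heavy atom, ortho to a large group, makes a difference that lies beyond the usual scatter. The bromo is still not needed for a low number, since compound 4, with a plain phenyl, gives 0.643 nM in this assay. Nothing measured here explains why the 2-bromophenyl compound has the lower number, so the step stands as an observation without a known cause.

The compounds shown leave open whether this step is specific to bromo or would also appear with another group on the same aromatic carbon, such as chloro, methyl or methoxy. Also open, as far as these compounds go, is whether the same change would give a step of similar size in compounds with a methyl or ethyl group on a nitrogen of the core, as in compound 3 and compound 2, which differ from compound 1 in more than one place.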